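A few compounds are considered here, and "the series" means these few. Any claim that something is new, unique, unknown or untested is made for them only; others in the source may bear on it.

Of the compounds shown here, three have been tested in a functional assay on DU-145 cells (Homo sapiens) for cytotoxicity, read by MTT assay, with a stated time of 24 h; a lower number here means a stronger inhibitor, a higher number a weaker inhibitor. Compound 1 (`CCCCCCCCCC(=O)Nc1nnc(S[C@@H]2O[C@H](CO)[C@H](O)[C@H](O)[C@H]2O)s1`) is recorded as "not active" (no number reported), with no number attached, and compound 2 (`CCCCCC(=O)Nc1nnc(S[C@@H]2O[C@H](CO)[C@H](O)[C@H](O)[C@H]2O)s1`) is likewise recorded as "not active" (no number reported). Compound 3 (`CCCCCCCC/C=C\CCCCCCCCCCCC(=O)Nc1nnc(S[C@@H]2O[C@H](COC(C)=O)[C@H](OC(C)=O)[C@H](OC(C)=O)[C@H]2OC(C)=O)s1`) is the only one with a figure, at 28400 nM. Compound 2 therefore holds no place on a numerical scale: it stands with compound 1 among the entries lacking a single number.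

The next compound, compound 4 (`C=CCCCCCCCCC(=O)Nc1nnc(S[C@@H]2O[C@H](CO)[C@H](O)[C@H](O)[C@H]2O)s1`), departs from compound 2 by one change, (pent-4-en-1-yl in place of hydrogen on a saturated chain carbon, five bonds along the chain from a carbonyl carbon). This puts pent-4-en-1-yl in place of hydrogen on a saturated chain carbon, five bonds along the chain from a carbonyl carbon.

Within the data shown here, no measured pair shows what such a change does in this assay, so the data cannot size this step. The expectation is for no clear gain in potency, resting on compound 2 at "not active" (no number reported) and compound 1 at "not active" (no number reported). Compound 4 may well be reported without a number too. Should a number appear, it is expected to lie in the weak range set by compound 3 at 28400 nM. The estimate for compound 4 is 60000 nM, with an expected range from 25000 nM to 150000 nM.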

Compound 4, half-maximal inhibitory concentration: "not active" (no number reported)
For compound 4 the study gives words and no number; the estimate stays without a comparison.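

In this assay compound 4, like compound 2, is recorded without a number, so no step can be read between the two. No measurement shown bears on this result. The compounds shown leave open whether pent-4-en-1-yl in place of hydrogen shifts the response in this assay at all.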